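This account rests on a few compounds, and the source may have more. Where it says the series, first, only, none or still open, it means among the compounds named here.

Working notes on the series. The shared core is carried by compound 1 `CS(=O)(=O)Nc1ccc2c(c1)S(=O)(=O)N=C(C1=C(O)C3CCCCC3N(Cc3ccc(F)cc3)C1=O)N2`, compound 2 `CS(=O)(=O)Nc1ccc2c(c1)S(=O)(=O)N=C(C1=C(O)C3CCCC3N(Cc3ccc(Cl)cc3)C1=O)N2` and compound 3 `CS(=O)(=O)Nc1ccc2c(c1)S(=O)(=O)N=C(C1=C(O)C3CCCCCCC3N(Cc3ccc(F)cc3)C1=O)N2`. In an ADME assay on Huh-7 cells (Homo sapiens) for cytotoxicity, with a stated time of 72 h (a lower number here means that less compound is tolerated, a higher number that more compound is tolerated), compound 1 gives > 33000 nM, which is a limit of the assay and not a number. In this assay compound 2 likewise gives only a limit, > 10000 nM. Compound 3 also gives a limit in this assay, > 33000 nM. Compound 2 thus stands at the limit of > 10000 nM in this assay, at which 1 of the 3 values shown sits, while the other two values sit at the limit of > 33000 nM in this assay, at which 2 of the 3 values shown sit; none of the three is a number, and nothing can be read from them beyond that all lie at or past their limits. For the measured compounds named here, no step between measured compounds can be computed.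

Compound 4 `CC(C)CCN1C(=O)C(C2=NS(=O)(=O)c3cc(NS(C)(=O)=O)ccc3N2)=C(O)C2CCCC21` is not yet measured in this assay. It differs from compound 2 in one place: isobutyl in place of 4-chlorophenyl on a saturated chain carbon bound to an amide-type nitrogen in a ring. Going by the values given here, since every value in this assay so far is a limit, the data give no ground for a step in either direction, and none beyond the scatter is expected. Accordingly the estimated step is a step that the limit leaves unreadable from compound 2 to compound 4, essentially none. For compound 4 in this assay the expected value is 30000 nM, within 10000 nM to 100000 nM, most likely again reported only as a limit.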

Compound 4, half-maximal cytotoxic concentration: > 1000 nM
Compound 4: no number, only a limit; the forecaster's own chance of this, stated with the estimate: 80%; the middle value does not contradict the limit.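

In this assay compound 4 gives > 1000 nM, which is a limit of the assay and not a number. Compound 2 likewise gives only a limit, > 10000 nM. No step can be read between compound 2 and compound 4. The compounds shown leave open where any of the four has an actual half-maximal cytotoxic concentration, and whether isobutyl in place of 4-chlorophenyl changes it.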